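The compounds below may be only part of what the source reports. "The series", "measured", "known", "first", "only" and "open" are said of these compounds alone.

Measured so far in a functional assay on HeLa cells (Homo sapiens) for antiproliferative activity, read by CCK-8 assay, with a stated time of 72 h, tested at 2 uM; a higher number here means a stronger effect of the compound at the concentration tested, a lower number a weaker effect:
compound 1 `Nc1ccccc1NC(=O)c1ccc(CSC(=S)N2CCN(c3ncccn3)CC2)cc1`: 52.2%
compound 2 `Nc1ccccc1NC(=O)c1ccc(CSC(=S)N2CCN(Cc3cccnc3)CC2)cc1`: 69.7%

Within the data shown here, compound 2 gives the highest of the two numbers in this assay; the single measured step, a number 17.5 percentage points higher from compound 1 to compound 2 (beyond the scatter), came with (pyridin-3-yl)methyl in place of pyrimidin-2-yl on an amine nitrogen in a ring, a change of both the ring and its attachment at once.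

Compound 3 `Nc1ccccc1NC(=O)c1ccc(CSC(=S)N2CCN(Cc3ccccc3)CC2)cc1` differs from compound 2 by phenyl in place of pyridin-3-yl on a saturated chain carbon bound to an amine nitrogen in a ring. Among the measured compounds shown here, no measured step isolates this exchange of the aromatic ring while the saturated chain carbon is kept, so the one step known does not bear on it directly; it only shows that alterations at this end of the core move the read-out by a modest amount. The expectation is a step of a number 4.7 percentage points lower from compound 2 to compound 3 (within the scatter), that is, nothing beyond the scatter in either direction. Compound 3 is therefore estimated at 65%, expected range 50% to 80%.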

Compound 3, a percentage reported as inhibition, at one concentration (the size of the read-out at that concentration, not a potency): 20.6%
Beside the measured number, compound 3's estimate is 44.4 percentage points above it, and the stated range ends above it.
By their numbers in this assay, from the lowest: compound 3; then compound 1; then compound 2.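

In this assay the step of a number 49.1 percentage points lower from compound 2 to compound 3 (beyond the scatter) comes with phenyl in place of pyridin-3-yl on a saturated chain carbon bound to an amine nitrogen in a ring, so with that carbon kept, the aromatic ring alone carries a large change, and the two rings differ only by one ring nitrogen in place of a carbon. Benzyl in place of pyrimidin-2-yl gives a number 31.6 percentage points lower from compound 1 to compound 3 (beyond the scatter), so the saturated chain carbon alone does not account for the higher number of the (pyridin-3-yl)methyl compound: compound 3 carries that carbon too and stands lowest of the three. Nothing available explains why this exchange has so large an effect.

From the compounds shown here alone, whether the ring nitrogen must sit where it does in pyridin-3-yl stays open, and (pyridin-2-yl)methyl or (pyridin-4-yl)methyl would address that. Also open, going by these compounds, is how a phenyl placed directly on the amine nitrogen, without the chain carbon, compares with pyrimidin-2-yl.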